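A few compounds are considered here, and "the series" means these few. Any claim that something is new, unique, unknown or untested is made for them only; others in the source may bear on it.

In a functional assay on the whole organism for inhibition, with Cavia porcellus as the target (a lower number here means that less compound is needed, a higher number that more compound is needed for the effect), compound 1 (`CCCC(=O)CC(=O)N1CCSC1COc1ccccc1OC`) gives 42 mg/kg and compound 2 (`CCOC(=O)CC(=O)N1CCSC1COc1ccccc1O`) gives 20 mg/kg as the lower of the two numbers, a gap beyond the scatter. Compound 3 (`O=C(O)CC(=O)N1CCSC1COc1ccccc1O`) follows from compound 2 through ethoxycarbonyl to carboxy, with hydrogen in place of ethyl on an oxygen next to a carbonyl group. Among the compounds with values here, no measured pair shows this change. A moderate estimated step (a 1.8-fold higher number from compound 2 to compound 3 (0.24 log units; within the scatter)) towards a higher number is expected in this assay with low confidence. For compound 3 the estimated value is 35 mg/kg (expected range 12 mg/kg to 100 mg/kg).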

Compound 3, dose for half-maximal effect: 25 mg/kg
Compound 3: middle estimate off by 1.4-fold (0.15 log units), on the high side; low and high end bracket the measured number.
By their numbers in this assay, from the lowest: compounds 2, 3 and 1 (each within the scatter of the next, the first and the last beyond it).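

In this assay, the change from ethoxycarbonyl to carboxy, with hydrogen in place of ethyl on an oxygen next to a carbonyl group, gives a 1.3-fold higher number from compound 2 to compound 3 (0.10 log units; within the scatter) and so no readable change. For this pair, the ethyl is not required to keep the number in the range of compound 2, and the ethoxycarbonyl and carboxy forms cannot be told apart.

From the compounds shown here alone, whether a primary amide or a longer-chain ester at this place would stay in the same range remains open. No measurement of any property bears on this result.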